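The compounds below may be only part of what the source reports. "The series", "measured", "known", "first", "only" and "open" are said of these compounds alone.

Measured so far in a functional assay on K562 cells (Homo sapiens) for cytotoxicity, read by MTT assay (a lower number here means a stronger inhibitor, a higher number a weaker inhibitor), for three compounds:
- Compound 1 `CCCSC1=CC(=O)C(C[C@]2(C)[C@@H](C)CC[C@]3(C)C(C)=CCC[C@@H]23)=CC1=O` gives 45500 nM
- Compound 2 `CC1=CCC[C@H]2[C@](C)(CC3=CC(=O)C4=C(SCCS4)C3=O)[C@@H](C)CC[C@]12C` gives 91000 nM
- Compound 3 `COC1=CC(=O)C=C(C[C@]2(C)[C@@H](C)CC[C@]3(C)C(C)=CCC[C@@H]23)C1=O` gives 2100 nM

Compound 3 has the lowest number of the three, well beyond the scatter from both others, which makes it the strongest inhibitor here. Compound 4 `CNC1=CC(=O)C=C(C[C@]2(C)[C@@H](C)CC[C@]3(C)C(C)=CCC[C@@H]23)C1=O` carries methylamino in place of methoxy on a double-bonded ring carbon. Among the compounds with values here, no measured pair shows this exchange alone, so any forecast is uncertain. A modest step in this assay towards a higher number, slightly beyond the scatter, is expected. The expected change is a 2.9-fold higher number from compound 3 to compound 4 (0.46 log units; beyond the scatter) in this estimate. For compound 4 the estimated value is 6000 nM with an expected range of 1500 nM to 25000 nM around it.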

Compound 4, half-maximal inhibitory concentration: 3600 nM
For compound 4 the middle estimate is 1.7-fold (0.22 log units) above the measured one, and the stated range covers the measured number.
By their numbers in this assay, from the lowest: compounds 3 and 4 (each within the scatter of the next); then compounds 1 and 2 (each within the scatter of the next).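

In this assay, methylamino in place of methoxy on this double-bonded ring carbon gives a 1.7-fold higher number from compound 3 to compound 4 (0.23 log units; within the scatter). Within the data shown here, this is the first direct reading of this position: methylamino brings a hydrogen-bond donor that methoxy lacks, yet the two compounds cannot be told apart in this assay. Nothing at hand explains this result.

Open, as far as these compounds go, is whether the position tolerates groups of other kinds, such as a longer chain on the nitrogen or a carboxylic acid. The compounds shown also leave open how an unsubstituted amine would compare with methylamino.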